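Nitro for bromo on the aryl ring: estimate for compound 4

The compounds below may be only part of what the source reports. "The series", "measured", "known", "first", "only" and "open" are said of these compounds alone.

The three measured compounds share one core and differ only in the aromatic group attached to the carbon with a double bond to nitrogen. In a functional assay on MCF7 cells (Homo sapiens) for antiproliferative activity, read by CCK-8 assay (on this read-out lower numbers stand for stronger inhibition and higher numbers for weaker inhibition), compound 1 `Fc1ccc(/C=N/c2nnc(SCc3c[se]c(-c4ccccc4)n3)s2)cc1` gives 10200 nM. Compound 2 `Brc1ccc(/C=N/c2nnc(SCc3c[se]c(-c4ccccc4)n3)s2)cc1` gives 14800 nM in this assay, and compound 3 `COc1cc(/C=N/c2nnc(SCc3c[se]c(-c4ccccc4)n3)s2)ccc1O` gives 15000 nM. Compound 2 thus stands second highest of the three numbers, with compound 3 nearest and compound 1 furthest, the change being a 1.5-fold higher number from compound 1 to compound 2 (0.16 log units; within the scatter) and a 1.0-fold higher number from compound 2 to compound 3 (0.01 log units; within the scatter); likewise a 1.5-fold higher number from compound 1 to compound 3 (0.17 log units; within the scatter). None of these steps exceeds the scatter.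

Compound 4 `O=[N+]([O-])c1ccc(/C=N/c2nnc(SCc3c[se]c(-c4ccccc4)n3)s2)cc1` differs from compound 2 by nitro in place of bromo on an aromatic carbon. Among the compounds with values here, the steps that bear on this change are the swap of one halogen for another at the same position, a 1.5-fold higher number from compound 1 to compound 2 (0.16 log units; within the scatter), and the swap of the whole aromatic group, a 1.0-fold higher number from compound 2 to compound 3 (0.01 log units; within the scatter), both within the scatter. Substituent changes at this position have so far left the numbers in this assay essentially flat, so for compound 4 no step beyond the scatter is expected, a 1.1-fold lower number from compound 2 to compound 4 (0.02 log units; within the scatter). The estimate for compound 4 in this assay is 14000 nM, with a range from 6000 nM to 32000 nM.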

Compound 4, half-maximal inhibitory concentration: 49100 nM
Compound 4: middle estimate off by 3.5-fold (0.54 log units), on the low side, outside the stated range (above it).
By their numbers in this assay, from the lowest: compounds 1, 2 and 3 (each within the scatter of the next); then compound 4.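

In this assay this position is no longer flat: nitro in place of bromo gives the clearest single-group change (a 3.3-fold higher number from compound 2 to compound 4 (0.52 log units; beyond the scatter)), and nitro in place of fluoro gives a step of the same direction (a 4.8-fold higher number from compound 1 to compound 4 (0.68 log units; beyond the scatter)). The 4-nitrophenyl group also separates from the 4-hydroxy-3-methoxyphenyl group (a 3.3-fold higher number from compound 3 to compound 4 (0.51 log units; beyond the scatter)), so compound 4 stands apart while compound 1, compound 2 and compound 3 remain within the scatter of one another, and the earlier flatness holds only for those three groups. Nothing available explains why nitro departs from the other groups.

Still open, from the compounds shown here alone, is whether the higher number belongs to nitro alone or would also appear with a nitrile, a carboxylic acid or an amine para to the same large group. Also open, going by these compounds, is whether nitro would give a similar step on another aromatic group within the shared core.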